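This account rests on a few compounds, and the source may have more. Where it says the series, first, only, none or still open, it means among the compounds named here.

Measured so far:
Compound 1 `C/C(=C\CC/C(C)=C/CC[C@@H]1[C@@]2(C)CCC(=O)C(C)(C)[C@H]2CC[C@@]1(C)O)CC/C=C(\C)C(=O)OCc1cn(-c2ccc(C(F)(F)F)cc2)nn1`: in an ADME assay on L132 cells (Homo sapiens) for cytotoxicity, read by MTT assay, with a stated time of 48 h (a higher number here means a weaker inhibitor, a lower number a stronger inhibitor), compound 1 gives > 150000 nM, a limit of the assay.
Compound 2 `C/C(=C\CC/C(C)=C/CC[C@@H]1[C@@]2(C)CCC(=O)C(C)(C)[C@H]2CC[C@@]1(C)O)CC/C=C(\C)C(=O)OCc1cn(-c2ccccc2)nn1`: in this assay compound 2 gives > 150000 nM, likewise a limit.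
Compound 3 `C/C(=C\CC/C(C)=C/CC[C@@H]1[C@@]2(C)CCC(=O)C(C)(C)[C@H]2CC[C@@]1(C)O)CC/C=C(\C)C(=O)OCc1cn(C[C@@H]2O[C@H](n3ccc(=O)[nH]c3=O)[C@H]3OC(C)(C)O[C@H]32)nn1`: in this assay compound 3 gives > 150000 nM, again a limit.

For the measured compounds named here, compound 2 thus stands at the limit, as do the other two values (the limit of > 150000 nM in this assay, at which 3 of the 3 values shown sit), and no compound can be ordered against another. Going by the values given here, the one step between measured compounds, a step that the two limits leave unreadable from compound 1 to compound 2, is unreadable, its two limits allowing no size. Compound 4 `C/C(=C\CC/C(C)=C/CC[C@@H]1[C@@]2(C)CCC(=O)C(C)(C)[C@H]2CC[C@@]1(C)O)CC/C=C(\C)C(=O)OCc1cn(-c2ccc(F)cc2)nn1` differs from compound 2 by fluoro in place of hydrogen on an aromatic carbon. Among the compounds with values here, no measured step bears on this change with a readable size. With every value shown sitting at the limit (the limit of > 150000 nM in this assay, at which 3 of the 3 values shown sit), compound 4 is expected to give a limit as well. The step that the limit leaves unreadable from compound 2 to compound 4 is therefore expected to stay within the scatter. The estimate for compound 4 is 200000 nM, range 150000 nM to 300000 nM.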

Compound 4, half-maximal inhibitory concentration: > 150000 nM
Compound 4 ended at the assay's limit; the forecaster's own chance of this, stated with the estimate: 90%; the middle value does not contradict the limit.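

The steps among compound 1, compound 2 and compound 4 cannot be read, as each value is a limit: the limit of > 150000 nM in this assay, at which 4 of the 4 values shown sit.

Still open, going by these compounds, is whether any compound of this series gives a readable value in this assay, and how the substituents on the phenyl group would then compare.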